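Lengthening the isothiocyanate chain on the hydroxylated analogue

The compounds below may be only part of what the source reports. "The series", "measured", "known", "first", "only" and "open" are said of these compounds alone.

Measured so far:
compound 1, `CN(C)C(=O)c1cc2cnc(Nc3ccc(C(=O)NCCCCN=C=S)cc3)nc2n1C1CCCC1`: 74.2%
compound 2, `CN(C)C(=O)c1cc2cnc(Nc3ccc(C(=O)NCCCN=C=S)cc3O)nc2n1C1CCCC1`: 24.2%

In a functional assay on NCI-H1299 cells (Homo sapiens) for inhibition, read by CCK-8 assay, with a stated time of 72 h, tested at 10 uM (on this read-out higher numbers stand for a stronger effect at the one concentration tested and lower numbers for a weaker effect), compound 2 gives 24.2%, the lowest of the two numbers measured; compound 1 gives 74.2%, a value higher by a margin beyond the usual scatter. Compound 1 and compound 2 differ in more than one place, so those two values alone do not show what any single change does.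

Compound 3 is `CN(C)C(=O)c1cc2cnc(Nc3ccc(C(=O)NCCCCN=C=S)cc3O)nc2n1C1CCCC1`. It differs from compound 2 in a single place: a group of 4 heavy atoms (2 carbon, 1 nitrogen, 1 sulfur; no ring) in place of a group of 3 heavy atoms (1 carbon, 1 nitrogen, 1 sulfur; no ring), on a saturated chain carbon, three bonds along the chain from an amide-type nitrogen. Among the compounds with values here, no pair of measured compounds differing only in this way is available, so the size of the step is uncertain. Compound 3 shares its longer chain with compound 1 and its hydroxylated ring with compound 2, so a value lying between the two measured numbers is expected, with a rise a number 15.8 percentage points higher from compound 2 to compound 3 (beyond the scatter) in this assay that may be no more than the scatter. Compound 3 is estimated at 40%, in a range from 15% to 70%.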

Compound 3, a percentage reported as inhibition, at one concentration (the size of the read-out at that concentration, not a potency): 51.8%
The estimate for compound 3 lay 11.8 percentage points below the measured number, and the stated range covers the measured number.
By their numbers in this assay, from the lowest: compound 2; then compound 3; then compound 1.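

In this assay, the longer isothiocyanate chain in place of the shorter one, with the hydroxylated ring kept, gives a number 27.6 percentage points higher from compound 2 to compound 3 (beyond the scatter), so chain length at this position changes the read-out on its own. With the longer chain kept, hydroxy in place of hydrogen on an aromatic carbon gives a number 22.4 percentage points lower from compound 1 to compound 3 (beyond the scatter), so the ring change also has a separate effect, in the opposite direction. The data on hand offer no explanation for either step. The compounds shown leave open whether a still longer chain on the hydroxylated ring would raise the number further or lower it. They also leave open whether the isothiocyanate itself is needed, a question that an amine at the end of the chain could address.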